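Half-life notes: from acetylpiperidine to acetylazetidine

The compounds below may be only part of what the source reports. "The series", "measured", "known", "first", "only" and "open" are said of these compounds alone.

Measured in an ADME assay on microsomes from liver (Mus musculus, strain CD-1) for metabolic stability, read by LC-MS, tested at 2 uM; a lower number here means that the compound disappears faster, a higher number that the compound lasts longer
- compound 1 `Cn1ccc2ccc(-c3cc(Nc4ccccc4S(=O)(=O)NCC4CCOCC4)cc4nccnc34)cc21` gives 0.3 h
- compound 2 `CC(=O)N1CCC(NC(=O)c2ccncc2Nc2cc(-c3ccc4ccn(C)c4c3)c3nccnc3c2)CC1` gives 0.117 h

Compound 2 stands lowest of the two, and the higher number of compound 1 lies beyond the scatter. Compound 3 `CC(=O)N1CC(NC(=O)c2ccncc2Nc2cc(-c3ccc4ccn(C)c4c3)c3nccnc3c2)C1` is not yet measured. It carries 1-acetylazetidin-3-yl in place of 1-acetylpiperidin-4-yl on an amide-type nitrogen. Within the data shown here, no measured step shows this change, so only a small rise, within the scatter, is expected. The expected change is a 1.5-fold higher number from compound 2 to compound 3 (0.16 log units; within the scatter). For compound 3 the estimated half-life is 0.17 h, with an expected range of 0.09 h to 0.35 h.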

Compound 3, half-life: 0.817 h
The estimate for compound 3 lay 4.8-fold (0.68 log units) below the measured number; measured number outside the range, above it.
By their numbers in this assay, from the lowest: compound 2; then compound 1; then compound 3.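

On the amide-type nitrogen, 1-acetylazetidin-3-yl in place of 1-acetylpiperidin-4-yl gives a 7.0-fold higher number from compound 2 to compound 3 (0.84 log units; beyond the scatter) in this assay. Half-life at this position therefore responds to the change from a six-membered to a four-membered ring, with the rest of the molecule held constant. No available data bear on the reason for this step.

From the compounds shown here alone, this remains a single step, so its transfer to other cores is unknown. Also open, going by these compounds, is whether a five-membered pyrrolidine ring, or a methanesulfonyl group in place of the acetyl on the azetidine, would give a comparable half-life.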